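The compounds below may be only part of what the source reports. "The series", "measured", "known", "first", "only" and "open" are said of these compounds alone.

Measured compounds and their values:
Compound 1 `COc1cccc(CNCCCNc2ccnc3cc(C4CCCCC4)ccc23)c1O` gives 9.47 in a physicochemical assay for acid dissociation.
Compound 2 `COc1ccc(F)cc1CNCCCNc1ccnc2cc(C3CCCCC3)ccc12` gives 9.47 in this assay.
Compound 3 `COc1cccc(CNCCCNc2ccnc3cc(-c4cc(C(F)(F)F)cc(C(F)(F)F)c4)ccc23)c1O` gives 9.47 in this assay.

The three measured values stand level with one another within the scatter of the measurement, so no ordering among compound 1, compound 2 and compound 3 can be read from them. Compound 1 and compound 2 differ in a single place, (5-fluoro-2-methoxyphenyl in place of 2-hydroxy-3-methoxyphenyl on a saturated chain carbon bound to an amine nitrogen), and this change made a step of no change at the digits printed from compound 1 to compound 2 (within the scatter). Compound 3 carries a different core from compound 1; the difference between the two cores is not broken down here, and what the two values show is that they sit together within the scatter.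

Compound 4 `COc1ccc(F)cc1CNCCCNc1ccnc2cc(-c3cc(C(F)(F)F)cc(C(F)(F)F)c3)ccc12` has not yet been measured. It is related to compound 3 by the same change that relates compound 1 to compound 2, namely (5-fluoro-2-methoxyphenyl in place of 2-hydroxy-3-methoxyphenyl on a saturated chain carbon bound to an amine nitrogen). The step is expected to be no change at the digits printed from compound 3 to compound 4 (within the scatter) in this assay, a repeat of the earlier one, because the same change from compound 1 to compound 2 made no change at the digits printed from compound 1 to compound 2 (within the scatter). On that basis compound 4 is estimated at 9.47, expected to fall between 9.15 and 9.8.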

Compound 4, acid dissociation constant: 9.47
For compound 4 middle estimate and measured number coincide at the digits printed; measured number inside the range.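

In this assay the replacement of 2-hydroxy-3-methoxyphenyl by 5-fluoro-2-methoxyphenyl made no change at the digits printed from compound 3 to compound 4 (within the scatter) on one core and no change at the digits printed from compound 1 to compound 2 (within the scatter) on the other, so the change gave the same outcome on both cores shown. Going by these compounds alone, this covers only two cores and a single change, and with both steps within the scatter it shows that the reading stayed level each time, not that a step of any real size carries from one core to another. Nothing available here bears on why the reading stays level under this change.

The compounds shown leave open whether the same result would hold on a third core, or for a replacement that puts a carboxylic acid or an amide on the benzyl group. They also leave open whether a longer chain in place of the saturated chain carrying the amine nitrogen would keep the reading level in this assay.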